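A few compounds are considered here, and "the series" means these few. Any claim that something is new, unique, unknown or untested is made for them only; others in the source may bear on it.

In a functional assay on MCF7 cells (Homo sapiens) for cytotoxicity, read by MTT assay, with a stated time of 72 h (on this read-out higher numbers stand for weaker inhibition and lower numbers for stronger inhibition), compound 1 `O=C(/C=C/c1ccc([N+](=O)[O-])cc1)Nc1cc2c(Nc3ccc(F)c(Cl)c3)ncnc2cc1O[C@H]1CCOC1` gives 26700 nM, compound 2 `COc1ccc(/C=C/C(=O)Nc2cc3c(Nc4ccc(F)c(Cl)c4)ncnc3cc2O[C@H]2CCOC2)c(OC)c1` gives 28600 nM and compound 3 `COc1cc(/C=C/C(=O)Nc2cc3c(Nc4ccc(F)c(Cl)c4)ncnc3cc2O[C@H]2CCOC2)cc(OC)c1OC` gives 28400 nM. Compound 3 therefore stands within the scatter of both other compounds. Compound 4 `COc1ccc(OC)c(/C=C/C(=O)Nc2cc3c(Nc4ccc(F)c(Cl)c4)ncnc3cc2O[C@H]2CCOC2)c1` differs from it by one change: 2,5-dimethoxyphenyl in place of 3,4,5-trimethoxyphenyl on a double-bonded chain carbon bound to a double-bonded chain carbon. Three measured swaps at this same place bear on the change: a 1.1-fold higher number from compound 1 to compound 2 (0.03 log units; within the scatter), a 1.1-fold higher number from compound 1 to compound 3 (0.03 log units; within the scatter) and a 1.0-fold lower number from compound 2 to compound 3 (0.00 log units; within the scatter). All three stay within the scatter, so no step beyond the scatter is expected in this assay for this further swap, although this group itself has not yet been measured. The expected step is a 1.0-fold lower number from compound 3 to compound 4 (0.01 log units; within the scatter). Compound 4 is estimated at 28000 nM, with an expected range from 17000 nM to 45000 nM.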

Compound 4, half-maximal inhibitory concentration: 36300 nM
Beside the measured number, compound 4's estimate is 1.3-fold (0.11 log units) below it, and the stated range covers the measured number.
By their numbers in this assay, from the lowest: compounds 1, 3, 2 and 4 (each within the scatter of the next).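

In this assay, the 2,5-dimethoxyphenyl group on the double-bonded chain carbon adds a fourth group at this position, and it too stays within the scatter of every earlier compound: a 1.3-fold higher number from compound 3 to compound 4 (0.11 log units; within the scatter), a 1.3-fold higher number from compound 2 to compound 4 (0.10 log units; within the scatter) and a 1.4-fold higher number from compound 1 to compound 4 (0.13 log units; within the scatter). Exchanging 2,4-dimethoxyphenyl for its 2,5-dimethoxyphenyl isomer therefore produces no step beyond the scatter either. Nothing available here accounts for this lack of separation. As far as these compounds go, whether an aminophenyl or carboxyphenyl group at this place would move the number beyond the scatter remains open.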